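A few compounds are considered here, and "the series" means these few. Any claim that something is new, unique, unknown or untested is made for them only; others in the source may bear on it.

Compound 1 `Cc1c(OCCCCOc2cccc(C(=O)O)c2)ccc(C(=O)CC2CCCC2)c1O`: 3400 nM
Compound 2 `Cc1cc(OCCCCOc2ccc(C(=O)CC(C)C)c(O)c2C)ccc1C(=O)O`: 3910 nM

Both numbers come from an assay on HEK293 cells for positive allosteric modulation of metabotropic glutamate receptor 3 (Rattus norvegicus), read by thallium flux, with a stated time of 2.5 min; a higher number here means that more compound is needed for the effect, a lower number that less compound is needed. Compound 2 gives 3910 nM and compound 1 gives 3400 nM. The two values lie within the scatter of repeated measurements, so neither compound can be set apart from the other on these numbers.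

Compound 3 `Cc1cc(OCCCCOc2ccc(C(=O)CC3CCCC3)c(O)c2C)ccc1C(=O)O` has not yet been measured. It keeps the core of compound 2 and differs from it in one place: cyclopentyl in place of isopropyl on a saturated chain carbon bound to a carbonyl carbon. For the measured compounds named here, no measured pair shows this change on its own; compound 1 and compound 2 differ in more than one place, so their gap cannot be credited to any single change. Still, compound 1 carries a cyclopentyl and compound 2 an isopropyl, and their values sit within the scatter, which gives no hint that this group moves the number far. The step from compound 2 to compound 3 in this assay is therefore expected to be small, a 1.2-fold lower number from compound 2 to compound 3 (0.09 log units; within the scatter), with no clear direction. Compound 3 is expected to give about 3200 nM, in a range from 1400 nM to 7500 nM.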

Compound 3, half-maximal effective concentration: > 10000 nM
Compound 3: no number, only a limit; the forecaster's own chance of this, stated with the estimate: 5%; middle value at least 3.1-fold (0.49 log units) from the limit.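

Cyclopentyl in place of isopropyl, on a saturated chain carbon bound to a carbonyl carbon, is not a neutral swap on this core: in this assay it gives an at least 2.5-fold higher number from compound 2 to compound 3 (0.40 log units; beyond the scatter). The same cyclopentyl is present in compound 1, which still gives a measurable value, and 4-carboxy-3-methylphenyl in place of 3-carboxyphenyl gives an at least 2.9-fold higher number from compound 1 to compound 3 (0.46 log units; beyond the scatter), so among these three compounds the effect of the cyclopentyl depends on the aryl acid at the far end of the molecule. The value for compound 3 is a limit and not a number, so both steps are minimum sizes: the limit of > 10000 nM in this assay, at which 1 of the 3 values shown sits.

As far as these compounds go, how far compound 3 really lies past that limit stays open. So does whether a cyclobutyl or a longer chain at this place would keep the activity on the core of compound 2.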